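This account rests on a few compounds, and the source may have more. Where it says the series, first, only, none or still open, it means among the compounds named here.

Values in an assay on CHO-K1 cells for activation of DNA damage-inducible transcript 3 protein (Homo sapiens), read by a luciferase reporter; on this read-out higher numbers stand for an effect only at larger amounts of compound and lower numbers for an effect already at smaller amounts:
compound 1 `O=C(Nc1ccc(S(=O)(=O)N2CCC(Cl)CC2)cc1)c1ccc([N+](=O)[O-])o1`: 800 nM
compound 2 `O=C(Nc1ccc(S(=O)(=O)c2ccccc2)cc1)c1ccc([N+](=O)[O-])o1`: 1100 nM

Going by the values given here, compound 2 carries the higher of the two numbers as read, but its only neighbour is compound 1 and the gap a 1.4-fold higher number from compound 1 to compound 2 (0.14 log units; within the scatter) lies within the scatter, so the two compounds count as equivalent on this read-out. Compound 3 `O=C(Nc1ccc(S(=O)(=O)C2CCCCC2)cc1)c1ccc([N+](=O)[O-])o1` has not been measured. It differs from compound 2 by cyclohexyl in place of phenyl on a sulfonyl sulfur. Among the compounds with values here, the one measured step that bears on this position is a 1.4-fold higher number from compound 1 to compound 2 (0.14 log units; within the scatter), in which a phenyl replaced a 4-chloropiperidin-1-yl on the same sulfonyl sulfur without a change beyond the scatter. That single comparison, between two rather different groups, gives no sign that the substituent on the sulfonyl sulfur moves the read-out much; it is a thin basis, and cyclohexyl itself has not been tried. The expected step of a 1.1-fold lower number from compound 2 to compound 3 (0.04 log units; within the scatter) is therefore none beyond the scatter, in either direction. Compound 3 is estimated at 1000 nM in this assay, with a range from 400 nM to 2500 nM.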

Compound 3, concentration for half-maximal activity: 700 nM
Compound 3: middle estimate off by 1.4-fold (0.15 log units), on the high side; the measured number falls inside the stated range.
By their numbers in this assay, from the lowest: compounds 3, 1 and 2 (each within the scatter of the next).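

In this assay, going by these compounds alone, the sulfonyl sulfur now carries three different groups, and no step between them goes beyond the scatter: cyclohexyl in place of phenyl gives a 1.6-fold lower number from compound 2 to compound 3 (0.20 log units; within the scatter) and cyclohexyl in place of 4-chloropiperidin-1-yl gives a 1.1-fold lower number from compound 1 to compound 3 (0.06 log units; within the scatter) in this series. The first of these steps adds something the earlier pair could not show, as it exchanges a six-membered aromatic ring of carbon only for a six-membered non-aromatic ring of carbon only, with the same heavy-atom count, and the read-out does not separate the two. Nothing measured here accounts for this lack of separation. 

Going by these compounds, all three compounds carry a six-membered ring on the sulfonyl sulfur, so it remains open whether the read-out stays this flat with a primary amine, a carboxylic acid or a short open chain such as ethyl at this place. The shared core is the same in all three compounds, so these data also say nothing about how the read-out responds to a change elsewhere in it.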